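The source may hold more compounds than are shown below. What is called first, only, known or untested is meant among the compounds shown, and "the series" means these compounds.

Working notes on the imidazoline series

Compound 1 `CCCn1ncnc1-c1ccccc1NCC1=NCCN1` carries a propyl chain on the aromatic nitrogen of the five-membered ring attached to the shared core. Among the measured compounds shown here, in an in vitro functional assay on cells (Fibroblast) for agonist activity at Alpha-1A adrenergic receptor (Homo sapiens) (a higher number here means that more compound is needed for the effect, a lower number that less compound is needed), compound 1 gives 12.6 nM, which is the lowest of the two numbers measured so far. Its nearest neighbour by value is compound 3 `Cc1nc(-c2ccccc2NCC2=NCCN2)n(C)n1`, which in this assay gives 1000 nM; that gap is well beyond the scatter of repeated measurements. Compound 2 `CC(C)n1nccc1-c1ccccc1NCC1=NCCN1` is recorded in this assay only as a limit, < 100000 nM, a reading at which no number was obtained (the limit of < 100000 nM in this assay, at which 1 of the 3 values shown sits). For the measured compounds named here, compounds 1 and 3 are not a single-point pair, so the data give no measured step between them.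

The next compound, compound 4 `CCn1ncnc1-c1ccccc1NCC1=NCCN1`, differs from compound 1 by one change: hydrogen in place of methyl on a saturated chain carbon, two bonds along the chain from an aromatic nitrogen. Going by the values given here, no measured step of this kind exists in the set, so the expectation rests on the size of the change alone, a single carbon removed from a chain that otherwise keeps the whole core of compound 1 intact. A small step is expected in this assay, if anything toward a slightly higher number, most likely not beyond the scatter; the expected step is a 1.6-fold higher number from compound 1 to compound 4 (0.20 log units; within the scatter).

Compound 4 is estimated to give 20 nM in this assay, with a range of 6 nM to 60 nM.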

Compound 4, half-maximal effective concentration: 1.26 nM
Beside the measured number, compound 4's estimate is 16-fold (1.20 log units) above it; measured number below the stated range.
By their numbers in this assay, from the lowest: compound 4; then compound 1; then compound 3.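

The position on a saturated chain carbon, two bonds along the chain from an aromatic nitrogen, is not silent in this assay: replacing methyl with hydrogen there, which turns propyl into ethyl, gives a 10-fold lower number from compound 1 to compound 4 (1.00 log units; beyond the scatter). Among the compounds shown here, this is the first measured single-place step, and it shows that a change of one carbon, with no ring, hydrogen-bond donor, hydrogen-bond acceptor or net charge entering or leaving, can move the number beyond the scatter, with the propyl chain not required for a low number on this core. Nothing in the data at hand accounts for the size of this step.

As far as these compounds go, a single step between two chain lengths fixes no trend, so it remains open whether the number keeps falling, levels off or turns upward along the chain, and a butyl chain or a branched chain such as isobutyl in the same place would begin to settle that. Also open, from the compounds shown here alone, is whether the position tolerates anything other than a plain alkyl chain, for instance a hydroxyl group or an amine at the end of the ethyl chain of compound 4.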